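The compounds below may be only part of what the source reports. "The series", "measured", "known", "first", "only" and "open" are said of these compounds alone.

In a functional assay on ML1 cells (Homo sapiens) for antiproliferative activity, read by WST assay, with a stated time of 3 days (on this read-out higher numbers stand for weaker inhibition and lower numbers for stronger inhibition), three compounds have been measured. Compound 1 `O=Cc1cc(=O)[nH]c(=O)n1[C@@H]1O[C@H](CO)[C@@H](O)[C@H]1O` gives > 50000 nM, which is a limit of the assay and not a number. Compound 2 `[N-]=[N+]=Nc1c(F)c(=O)[nH]c(=O)n1[C@@H]1O[C@H](CO)[C@@H](O)[C@H]1O` gives 600 nM, and compound 3 `Nc1c(F)c(=O)[nH]c(=O)n1[C@@H]1O[C@H](CO)[C@@H](O)[C@H]1O` gives 700 nM. The step of a 1.2-fold higher number from compound 2 to compound 3 (0.07 log units; within the scatter), with amino in place of azido on an aromatic carbon, leaves compound 3 level with compound 2.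

Compound 4 `O=Cc1c(F)c(=O)[nH]c(=O)n1[C@@H]1O[C@H](CO)[C@@H](O)[C@H]1O` has not yet been measured. The change is formyl in place of amino on an aromatic carbon, ortho to a fluoro group. Going by the values given here, the one measured step involves azido rather than formyl, so it bears on this change only indirectly. Among the compounds with values here, compound 1 is the only measured compound with a formyl group, though it lacks the fluoro group, and its > 50000 nM is again a limit. A clear rise in the number in this assay, beyond the scatter, is therefore expected, though its size is uncertain. The expected change is an 8.6-fold higher number from compound 3 to compound 4 (0.93 log units; beyond the scatter). Compound 4 is estimated at 6000 nM, with an expected range from 700 nM to 50000 nM.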

Compound 4, half-maximal inhibitory concentration: 300 nM
Estimate against measurement, compound 4: 20-fold (1.30 log units) above; the measured number lies below the stated range.
By their numbers in this assay, from the lowest: compounds 4, 2 and 3 (each within the scatter of the next, the first and the last beyond it). At a limit, above all of these: compound 1.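

In this assay, a formyl group on this aromatic carbon, next to the ring nitrogen and ortho to a fluoro group, gives a 2.3-fold lower number from compound 3 to compound 4 (0.37 log units; beyond the scatter), and against azido at the same place it gives a 2.0-fold lower number from compound 2 to compound 4 (0.30 log units; within the scatter), so this position accepts a carbonyl-bearing group as well as the two nitrogen groups. The value of compound 1, which has hydrogen in place of the fluoro group, is a limit of the assay and not a number: the limit of > 50000 nM in this assay, at which 1 of the 4 values shown sits. Fluoro in place of hydrogen gives an at least 160-fold lower number from compound 1 to compound 4 (2.22 log units; beyond the scatter), so the formyl group alone does not account for the number of compound 4.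

The compounds shown leave open how a carboxylic acid, a hydroxymethyl group or a nitrile would fare at this position. They also leave open whether chlorine could stand in place of the fluoro group, and what the fluoro group contributes alongside amino or azido.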